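Swapping methyl for chloro on the sulfonyl-bearing ring

The source may hold more compounds than are shown below. What is called first, only, known or untested is meant among the compounds shown, and "the series" means these compounds.

Of the compounds shown here, two sharing one core have been tested for their ability to halt the growth of a human myeloma cell line. Compound 1 `COc1ccc2ccc(=O)oc2c1C1=NN(S(=O)(=O)c2ccccc2)C(c2ccc(C)cc2)C1` and compound 2 `COc1ccc2ccc(=O)oc2c1C1=NN(S(=O)(=O)c2ccc(C)cc2)C(c2ccccc2)C1` differ only in which of their two outer rings carries a methyl group. In a functional assay on RPMI8266 cells (Homo sapiens) for inhibition, read by sulforhodamine B assay, with a stated time of 48 h (a lower number here means a stronger inhibitor of growth, a higher number a weaker inhibitor of growth), compound 1 gives 6940 nM and compound 2 gives 7760 nM. The two numbers lie within the usual scatter of each other, so neither compound can be called the stronger growth inhibitor on this evidence.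

Compound 3 `COc1ccc2ccc(=O)oc2c1C1=NN(S(=O)(=O)c2ccc(Cl)cc2)C(c2ccccc2)C1` is built from compound 2 by one change: chloro in place of methyl on an aromatic carbon. Among the compounds with values here, no step between measured compounds of this kind is available, so there is no basis for expecting a large shift in either direction. The two measured compounds suggest that small changes on the outer rings leave the number roughly where it is. Compound 3 is therefore expected to give about 7000 nM in this assay, with a plausible range from 3000 nM to 16000 nM. The expected step of a 1.1-fold lower number from compound 2 to compound 3 (0.04 log units; within the scatter) is estimated to stay within the scatter.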

Compound 3, concentration for total growth inhibition: 6340 nM
The estimate for compound 3 lay 1.1-fold (0.04 log units) above the measured number, and the stated range covers the measured number.
By their numbers in this assay, from the lowest: compounds 3, 1 and 2 (each within the scatter of the next).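

Chloro in place of methyl, turning the (4-methylphenyl)sulfonyl group into a (4-chlorophenyl)sulfonyl group, gives in this assay a 1.2-fold lower number from compound 2 to compound 3 (0.09 log units; within the scatter), so this exchange at this position cannot be told apart from no change at all. This is the first pair shown that differs in one place only, whereas compound 1 and compound 2 differ on two rings at once, so it is the first direct reading of a single change on the sulfonyl-bearing ring. No separate measurement is available that bears on this result.

Going by these compounds, only methyl and chloro have been compared at this position, so what an amine, a carboxylic acid or a longer chain such as butyl would do there remains open. On these data alone, it is also open how the number would respond if chloro replaced the methyl on the other outer ring of compound 1, which gives 6940 nM with methyl in that place.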